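Replacing dipropylamino: from compound 3 to compound 4

The source may report more compounds than this note shows. Statements on the series, on what has been measured and on what is new or still open speak of the compounds shown alone.

- compound 1 `CCNc1ccc(NC(=O)c2cc(Cl)ccc2O)c(Cl)c1`: 30200 nM
- compound 2 `CC1(Nc2ccc(NC(=O)c3cc(Cl)ccc3O)c(Cl)c2)CCCC1`: 157000 nM
- compound 3 `CCCN(CCC)c1ccc(NC(=O)c2cc(Cl)ccc2O)c(Cl)c1`: 10700 nM

In an ADME assay on A549 cells (Homo sapiens) for cytotoxicity, read by resazurin assay, with a stated time of 48 h (on this read-out lower numbers stand for higher toxicity in this test and higher numbers for lower toxicity in this test), compound 3 gives the lowest of the three numbers, 10700 nM. Compound 4 `O=C(Nc1ccc(NCc2ccc(F)cc2)cc1Cl)c1cc(Cl)ccc1O` carries (4-fluorobenzyl)amino in place of dipropylamino on an aromatic carbon. Among the measured compounds shown here, no measured compound carries this group, so the evidence is indirect. Both measured steps into dipropylamino lower the number: a 2.8-fold lower number from compound 1 to compound 3 (0.45 log units; beyond the scatter) is modest and a 15-fold lower number from compound 2 to compound 3 (1.17 log units; beyond the scatter) is large. Leaving dipropylamino is therefore expected to raise the number in this assay, though the gap of a 5.2-fold higher number from compound 1 to compound 2 (0.72 log units; beyond the scatter) shows that the two other amino groups differ widely. The expected change is modest: a 2.3-fold higher number from compound 3 to compound 4 (0.37 log units; beyond the scatter). For compound 4 the estimate is 25000 nM, with an expected range of 8000 nM to 80000 nM.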

Compound 4, half-maximal cytotoxic concentration: 54400 nM
Compound 4: the middle estimate sits 2.2-fold (0.34 log units) below what was measured; the range from low to high includes it.
By their numbers in this assay, from the lowest: compound 3; then compounds 1 and 4 (each within the scatter of the next); then compound 2.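

In this assay, a secondary amine carrying an aromatic ring stays clear of the dipropylamino compound (a 5.1-fold higher number from compound 3 to compound 4 (0.71 log units; beyond the scatter)), so all three compounds with a hydrogen-bond donor on this nitrogen now stand above compound 3. The 1-methylcyclopentyl group still gives a separate, higher number (a 2.9-fold lower number from compound 2 to compound 4 (0.46 log units; beyond the scatter)). The 4-fluorobenzyl and ethyl groups are not separated (a 1.8-fold higher number from compound 1 to compound 4 (0.26 log units; within the scatter)), which is within the scatter.

Unsubstituted benzylamino would test the fluorine, and N-methyl-(4-fluorobenzyl)amino would test the hydrogen on the nitrogen. No measurement at hand explains these differences.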